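Methyl in place of hydrogen at two different ring positions

This account rests on a few compounds, and the source may have more. Where it says the series, first, only, none or still open, it means among the compounds named here.

Of the compounds shown here, three are measured so far. In a functional assay on MDA-MB-231 cells (Homo sapiens) for antiproliferative activity, read by MTT assay, with a stated time of 48 h (a higher number here means a weaker inhibitor, a lower number a stronger inhibitor), compound 1 `Cc1ccc2nc(Nc3nc(Nc4ccc(S(N)(=O)=O)cc4)ncc3F)sc2c1` gives 6390 nM. Compound 2 `NS(=O)(=O)c1ccc(Nc2ncc(F)c(Nc3nc4ccccc4s3)n2)cc1` gives 22600 nM in this assay. Compound 3 `CS(=O)(=O)c1ccc(Nc2nccc(Nc3nc4ccc(F)cc4s3)n2)cc1` gives 2080 nM in this assay, the lowest of the three numbers; its nearest neighbour is compound 1 and the furthest is compound 2. The difference between the core of compound 2 and the core of compound 3 is not broken down here.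

One single-point step is measured: methyl in place of hydrogen on an aromatic carbon gave a 3.5-fold lower number from compound 2 to compound 1 (0.55 log units; beyond the scatter).

Compound 4 `Cc1cnc(Nc2ccc(S(C)(=O)=O)cc2)nc1Nc1nc2ccc(F)cc2s1` is not yet measured. From compound 3 it differs by methyl in place of hydrogen on an aromatic carbon. Among the compounds with values here, this is the same kind of change as the one from compound 2 to compound 1, not the same change: there the methyl enters on an aromatic carbon of a six-membered aromatic ring of carbon only, part of a fused or bridged system of two rings, meta to a fused ring and para to a fused ring, whereas here it enters on a six-membered aromatic ring with 2 nitrogen, ortho to a large group, two atoms from the ring nitrogen and para to a large group.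

For compound 4 a step of about a 1.5-fold lower number from compound 3 to compound 4 (0.17 log units; within the scatter) is expected. Within the data shown here, this expectation rests on the only measured methyl step, a 3.5-fold lower number from compound 2 to compound 1 (0.55 log units; beyond the scatter). Among the measured compounds shown here, that step is discounted here: the place of the methyl differs, and the sole precedent is a single pair. Compound 4 is therefore expected to give about 1400 nM in this assay, with a likely range from 500 nM to 4500 nM.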

Compound 4, half-maximal inhibitory concentration: > 50000 nM
Compound 4: only a limit was reported (the forecaster's own chance of this, stated with the estimate: 3%); middle value at least 35-fold (1.55 log units) away from the limit.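

Placed on the six-membered aromatic ring with 2 nitrogen, methyl in place of hydrogen gives an at least 24-fold higher number from compound 3 to compound 4 (1.38 log units; beyond the scatter) in this assay, whereas on the core of compound 2 it gave a 3.5-fold lower number from compound 2 to compound 1 (0.55 log units; beyond the scatter). The change therefore does not carry over from one core to the other in this series, and the earlier step gives no usable guide to its size or direction on the core of compound 3: the same change on two cores in this assay, a 3.5-fold lower number (0.55 log units; beyond the scatter) from compound 2 to compound 1 and an at least 24-fold higher number (1.38 log units; beyond the scatter) from compound 3 to compound 4, at least 85-fold (1.92 log units) apart, beyond the scatter of two such steps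

Compound 4 is reported only as a limit of the assay, > 50000 nM, so the full size of its step is unknown, and with a single pair on each core the data do not show whether the place of the methyl, the rest of the core or both separate the two outcomes: the limit of > 50000 nM in this assay, at which 1 of the 4 values shown sits.

Still open, as far as these compounds go, is whether the loss on the core of compound 3 is specific to methyl, or whether a chlorine, a methoxy or an amine on the same ring carbon would behave alike. Also open, from the compounds shown here alone, is whether methyl on the other ring of the core of compound 3, where the fluorine-bearing part lies, would follow the step seen for the core of compound 2.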